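Compound 3 to compound 4: a series at its limit

This account rests on a few compounds, and the source may have more. Where it says the series, first, only, none or still open, it means among the compounds named here.

Measured in an ADME assay on HEK293 cells (Homo sapiens) for cytotoxicity, read by MTT assay, with a stated time of 36 h (a lower number here means a stronger inhibitor, a higher number a weaker inhibitor), with each value a limit and not a number:
- Compound 1 `O=C(c1ccc2c(c1)OCCO2)C1CCN(Cc2coc(-c3ccc(Br)cc3)n2)CC1` gives > 150 ug/mL (a limit)
- Compound 2 `O=C(c1ccc2c(c1)OCCO2)C1CCN(Cc2coc(-c3ccccc3)n2)CC1` gives > 150 ug/mL (a limit)
- Compound 3 `O=C(c1ccc2c(c1)OCCO2)C1CCN(Cc2coc(-c3ccc(C(F)(F)F)cc3)n2)CC1` gives > 150 ug/mL (a limit)

Compound 3 has no number, only the limit > 150 ug/mL in this series. For the measured compounds named here, the whole set so far is described by the limit of > 150 ug/mL in this assay, at which 3 of the 3 values shown sit, and no compound has yet given a number.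

The next structure is compound 4 `O=C(c1ccc2c(c1)OCCO2)C1CCN(Cc2coc(-c3cccc(F)c3)n2)CC1` with 3-fluorophenyl in place of 4-(trifluoromethyl)phenyl on an aromatic carbon, counted as 3-fluorophenyl in place of 4-(trifluoromethyl)phenyl on an aromatic carbon here.

Going by the values given here, three measured steps bear on this change, all on the same aromatic ring. They are a step that the two limits leave unreadable from compound 1 to compound 2 and a step that the two limits leave unreadable from compound 1 to compound 3 and a step that the two limits leave unreadable from compound 2 to compound 3 and none has a size that can be read. Among the compounds with values here, no fluoro compound has been measured.

No step beyond the scatter is expected in this assay and no direction can be named, an expectation that rests on the limit of compound 3 at > 150 ug/mL and on nothing finer. The expected outcome is a step that the limit leaves unreadable from compound 3 to compound 4 in size. The estimate for compound 4 is 200 ug/mL with an expected range from 130 ug/mL to 400 ug/mL and a report as a limit is the likeliest result.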

Compound 4, half-maximal inhibitory concentration: > 150 ug/mL
Compound 4 was reported as a limit; the forecaster's own chance of this, stated with the estimate: 85%; the middle value does not contradict the limit.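

In this assay compound 4 gives > 150 ug/mL, a limit and not a number, so its steps to compound 1, compound 2 and compound 3 cannot be read: the limit of > 150 ug/mL in this assay, at which 4 of the 4 values shown sit.

The compounds shown leave open whether any change on this aromatic ring would give a number in this assay, and how these four compounds rank.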